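The source may report more compounds than this note shows. Statements on the series, on what has been measured and on what is new or still open speak of the compounds shown alone.

Measured compounds:
- compound 1, `O=C(O)c1csc([C@H]2CC[C@@H]3[C@@H](/C=C/CCCOc4ccccc4)[C@H](O)C[C@@H]3O2)n1`: 970 nM
- compound 2, `O=C(O)c1csc([C@H]2CC[C@@H]3[C@@H](CCCCCOc4ccccc4)[C@H](O)C[C@@H]3O2)n1`: "not determined" (no result reported)

Going by the values given here, compound 1 is the only compound of this set with a number in a functional assay on CHO cells for agonist activity at prostaglandin E2 receptor EP1 subtype (Homo sapiens), read by fluorescence and calcium flux; a lower number here means that less compound is needed, a higher number that more compound is needed for the effect; in that assay compound 1 gives 970 nM. Compound 2 shares the core of compound 1, but for compound 2 in this assay the entry reads "not determined" (no result reported), so no comparison with compound 1 can be drawn. Compound 3, `O=C(O)c1csc([C@H]2CC[C@@H]3[C@@H](/C=C/CCOc4ccccc4)[C@H](O)C[C@@H]3O2)n1`, is not yet measured. It differs from compound 1 in one place: phenoxy in place of phenoxymethyl on a saturated chain carbon, two bonds along the chain from a double-bonded chain carbon. Among the compounds with values here, no step between two measured compounds is available that would show how this assay answers a change of this kind, so the expectation rests on the single value of compound 1. Compound 3 is expected to need somewhat more compound than compound 1, a step of a 2.1-fold higher number from compound 1 to compound 3 (0.31 log units; beyond the scatter) that may not clearly exceed the usual scatter. The estimate for compound 3 in this assay is 2000 nM, within a range from 500 nM to 8000 nM.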

Compound 3, half-maximal effective concentration: 160 nM
Beside the measured number, compound 3's estimate is 13-fold (1.10 log units) above it, and the stated range ends above it.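

In this assay, going by these compounds alone, putting phenoxy in place of phenoxymethyl on a saturated chain carbon, two bonds along the chain from a double-bonded chain carbon, gives a 6.1-fold lower number from compound 1 to compound 3 (0.78 log units; beyond the scatter), which shows that the assay responds to a change at this position, something the single value of compound 1 could not show. Read one bond further out, the same difference is 3-phenoxypropyl to 2-phenoxyethyl, so here the side chain with one carbon fewer needs less compound, though this single pair sets no trend. Nothing measured here bears on the reason for this step.

On these data alone, what the double bond in the chain contributes stays open, with compound 2 carrying no number in this assay. Also open, as far as these compounds go, is whether a still shorter chain, or an anilino group or a fluorophenoxy group at the chain end, would follow the same direction.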